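Swapping the Amide Aryl Group on a Pyridylpiperazine Core

This account rests on a few compounds, and the source may have more. Where it says the series, first, only, none or still open, it means among the compounds named here.

Measured so far:
compound 1, `Cc1cccc(NC(=O)CN2CCC(c3ccc(Cl)cc3)CC2)c1`, gives "not active" (no number reported) in an assay on cells for agonist activity at D(4) dopamine receptor (Homo sapiens), read by luminescence and beta-arrestin recruitment, with a stated time of 90 min; a higher number here means that more compound is needed for the effect, a lower number that less compound is needed
compound 2, `O=C(CN1CCN(c2ccccn2)CC1)Nc1cccnc1`, gives 2660 nM in this assay
compound 3, `Cc1cccc(NC(=O)CN2CCC(c3ccccc3)CC2)c1`, gives 242 nM in this assay

Compound 2 stands at the highest of the two numbers reported. Compound 3 lies well below it, and that gap is beyond the usual scatter of repeated measurements. Compound 1 has no number at all in this assay.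

Compound 4, `CCc1cccc(NC(=O)CN2CCN(c3ccccn3)CC2)c1`, has not yet been measured. It differs from compound 2 in one place: 3-ethylphenyl in place of pyridin-3-yl on an amide-type nitrogen. Going by the values given here, no pair of measured compounds differs in exactly one place, so no measured step tells directly what this change does. Still, compound 3 also carries a six-membered aromatic ring of carbon only on its amide-type nitrogen, and compound 3 gives 242 nM.

A downward step is expected, that is less compound needed, a 5.9-fold lower number from compound 2 to compound 4 (0.77 log units; beyond the scatter), and the size is a guess resting on compound 3 alone. Compound 4 is therefore estimated at 450 nM, with a range from 120 nM to 2000 nM.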

Compound 4, half-maximal effective concentration: 133 nM
Estimate against measurement, compound 4: 3.4-fold (0.53 log units) above; the measured number falls inside the stated range.
By their numbers in this assay, from the lowest: compounds 4 and 3 (each within the scatter of the next); then compound 2.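

In this assay the swap of pyridin-3-yl for 3-ethylphenyl on the amide-type nitrogen gives a 20-fold lower number from compound 2 to compound 4 (1.30 log units; beyond the scatter) and so shows directly that this position strongly affects how much compound is needed. The change is a double one, since the ring loses its nitrogen and also gains an ethyl group, and this single step cannot divide the effect between the two. Nothing measured here explains why the number falls.

As far as these compounds go, how much of the step belongs to the ring and how much to the ethyl group remains open, and a plain phenyl group on the same core would help separate the two. Also open, from the compounds shown here alone, is how a longer chain such as propyl, or a methoxy group, on that ring would move the number.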